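The source may hold more compounds than are shown below. What is called first, only, known or untested is meant among the compounds shown, and "the series" means these compounds.

The measured compounds in an assay on cells with melanin-concentrating hormone receptor 1 (Homo sapiens) as the target, read by radioligand binding; a higher number here means a weaker inhibitor, a lower number a stronger inhibitor:
compound 1, `Nc1ccc2cccc(OC3CCCCC3)c2n1`, gives 361 nM;
compound 2, `COCC(C)Oc1cccc2ccc(N)nc12`, gives 606 nM;
compound 3, `CC1CC1COc1cccc2ccc(N)nc12`, gives 1640 nM.

Among these three numbers compound 2 stands second highest. Its nearest neighbour is compound 1, with a 1.7-fold higher number from compound 1 to compound 2 (0.22 log units; within the scatter). Its furthest is compound 3, with a 2.7-fold higher number from compound 2 to compound 3 (0.43 log units; beyond the scatter).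

Compound 4, `CCC(CC)C(C)Oc1cccc2ccc(N)nc12`, differs from compound 2 in one place: pentan-3-yl in place of methoxymethyl on a saturated chain carbon bound to an oxygen on an aromatic ring and a saturated chain carbon. Within the data shown here, two measured steps bear on this. The step from compound 1 to compound 2 swapped cyclohexyl for 1-(methoxymethyl)ethyl on the oxygen on the aromatic ring, with a 1.7-fold higher number from compound 1 to compound 2 (0.22 log units; within the scatter), a step within the scatter. The step from compound 1 to compound 3, with a 4.5-fold higher number from compound 1 to compound 3 (0.66 log units; beyond the scatter), shows that a different hydrocarbon group on that oxygen can also weaken binding, so the direction is not settled by the shape of the group alone. On balance, the closest comparison is compound 1, whose hydrocarbon group gave a number near that of compound 2, so the number for compound 4 is expected to move only slightly, a 1.4-fold lower number from compound 2 to compound 4 (0.16 log units; within the scatter), a step within the scatter. The estimate for compound 4 in this assay is therefore 420 nM, with a range from 150 nM to 1200 nM.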

Compound 4, half-maximal inhibitory concentration: 191 nM
Compound 4: middle estimate off by 2.2-fold (0.34 log units), on the high side, within the range that was stated.
By their numbers in this assay, from the lowest: compounds 4, 1 and 2 (each within the scatter of the next, the first and the last beyond it); then compound 3.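

In this assay, the exchange of methoxymethyl for pentan-3-yl on a saturated chain carbon bound to an oxygen on an aromatic ring and a saturated chain carbon gives a 3.2-fold lower number from compound 2 to compound 4 (0.50 log units; beyond the scatter), the first change shown within the group on that oxygen rather than of the whole group. Methoxymethyl carries an oxygen and a hydrogen-bond acceptor and pentan-3-yl carries neither, so the lower number of compound 4 shows that this oxygen and acceptor are not required at this position for binding in this assay. Nothing shown accounts for the step, and this single exchange cannot separate the loss of the oxygen from the larger all-carbon group that enters.

The compounds shown leave open whether a shorter chain such as ethyl, or a ring such as phenyl, on the same carbon would also give a lower number than compound 2. They also leave open where hydroxymethyl or an amine at that place would fall relative to compound 2 and compound 4.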